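A few compounds are considered here, and "the series" means these few. Any claim that something is new, unique, unknown or untested is made for them only; others in the source may bear on it.

Compound 1 `CCCn1c(=O)c2nc(-c3ccc(OCC(=O)O)cc3O)[nH]c2n(CCC)c1=O` and compound 2 `CCCn1c(=O)c2nc(-c3ccc(OCC(N)=O)cc3O)[nH]c2n(CCC)c1=O` share one core. In an assay on membranes from brain for antagonist activity at adenosine receptor A1 (Rattus norvegicus) (a lower number here means a stronger inhibitor, a higher number a weaker inhibitor), compound 1 gives 37 nM, and compound 2 gives 6.5 nM. Among the compounds with values here, the one recorded step, a 5.7-fold lower number from compound 1 to compound 2 (0.76 log units; beyond the scatter), is amino in place of hydroxy on a carbonyl carbon. Compound 2 thus stands at the lowest of the two numbers, with compound 1 the nearest at a higher value. Compound 3 `CCCn1c(=O)c2nc(-c3ccc(OCC(=O)NCCN(C)C)cc3O)[nH]c2n(CCC)c1=O` is compound 2 with 2-(dimethylamino)ethyl in place of hydrogen on an amide-type nitrogen. Within the data shown here, no recorded step bears directly on this change: the only measured step, a 5.7-fold lower number from compound 1 to compound 2 (0.76 log units; beyond the scatter), concerns what sits on the carbonyl carbon, not what sits on the amide nitrogen, so it gives no direction of its own for this move. With nothing pointing either way, the expected step in this assay is a 1.2-fold higher number from compound 2 to compound 3 (0.09 log units; within the scatter), nothing beyond the scatter. Compound 3 is estimated at 8 nM, within a range from 2.5 nM to 25 nM.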

Compound 3, antagonist equilibrium constant: 8.4 nM
The estimate for compound 3 lay 1.1-fold (0.02 log units) below the measured number; the range from low to high includes it.
By their numbers in this assay, from the lowest: compounds 2 and 3 (each within the scatter of the next); then compound 1.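

On the amide-type nitrogen, 2-(dimethylamino)ethyl in place of hydrogen gives a 1.3-fold higher number from compound 2 to compound 3 (0.11 log units; within the scatter) in this assay, so this position accepts this chain with no step beyond the scatter. The lower number relative to the carboxylic acid compound 1 also persists when the amide hydrogen is replaced, with a 4.4-fold lower number from compound 1 to compound 3 (0.64 log units; beyond the scatter). No supporting measurement is available to explain these numbers.

As far as these compounds go, it remains open whether a longer chain on this nitrogen, or a primary amine in place of the dimethylamino group, would also stay within the scatter of compound 2. A chain ending in a carboxylic acid or a phenyl ring would test whether this tolerance extends beyond the one substituent shown here.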